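The source may report more compounds than this note shows. Statements on the series, on what has been measured and on what is new or still open speak of the compounds shown alone.

Measured so far in a functional assay on MCF7 cells (Homo sapiens) for cytotoxicity, read by MTT assay, with a stated time of 24 h; on this read-out higher numbers stand for weaker inhibition and lower numbers for stronger inhibition 
- compound 1 `COc1cc2ncnc(Nc3cccc(C(F)(F)F)c3)c2cc1OCCCSc1nc2ccccc2o1` gives 4030 nM 
- compound 2 `CCc1cc(Br)ccc1Nc1ncnc2cc(OC)c(OCCCSc3nc4ccccc4o3)cc12` gives 17300 nM 

Compound 2 holds the higher of the two numbers at 17300 nM so far. Compound 3 `CCCCc1nc(Cl)c(C=O)n1CCCOc1cc2c(Nc3ccc(Br)cc3CC)ncnc2cc1OC` differs from compound 2 at the chain end only: 2-butyl-4-chloro-5-formyl-1H-imidazol-1-yl in place of (1,3-benzoxazol-2-yl)sulfanyl on a saturated chain carbon, three bonds along the chain from an oxygen on an aromatic ring is the whole change. Among the compounds with values here, the only measured step, a 4.3-fold higher number from compound 1 to compound 2 (0.63 log units; beyond the scatter) here, is modest and concerns the group on the nitrogen, not the chain end, so it suggests a size but no direction. A step of similar or smaller size is expected in this assay with a slight lean to a lower number. The estimated change is a 1.7-fold lower number from compound 2 to compound 3 (0.24 log units; within the scatter) overall. For compound 3 the estimate is 10000 nM with an expected range of 2500 nM to 40000 nM in this assay.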

Compound 3, half-maximal inhibitory concentration: 6560 nM
Beside the measured number, compound 3's estimate is 1.5-fold (0.18 log units) above it; the range from low to high includes it.
By their numbers in this assay, from the lowest: compounds 1 and 3 (each within the scatter of the next); then compound 2.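

In this assay, the chain end proves to be a position that moves the read-out: 2-butyl-4-chloro-5-formyl-1H-imidazol-1-yl in place of (1,3-benzoxazol-2-yl)sulfanyl gives a 2.6-fold lower number from compound 2 to compound 3 (0.42 log units; beyond the scatter) and shows that this position matters as well as the group on the nitrogen. The swap changes the ring set and the hetero atoms together, so no single part of the entering group can be singled out. No available evidence explains the change. Still open, on these data alone, is whether an amine, a carboxylic acid or a longer chain at this position would shift the number further. Also open, as far as these compounds go, is whether the step holds with 3-(trifluoromethyl)phenyl on the nitrogen.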